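Cathepsin S nitriles: ether oxygen in the side chain

This account rests on a few compounds, and the source may have more. Where it says the series, first, only, none or still open, it means among the compounds named here.

Compound 1 `N#C[C@H](CCc1ccccc1)NC(=O)[C@@H](CC(=O)N1CCOCC1)CC1CCCCC1` and compound 2 `N#C[C@@]1(NC(=O)[C@@H](CC(=O)N2CCOCC2)CC2CCc3ccccc3C2)CCN(C2CCCCC2)C1` share a nitrile-bearing core. In an assay on isolated protein for inhibition of cathepsin S (Homo sapiens) (on this read-out higher numbers stand for weaker binding and lower numbers for tighter binding), compound 1 gives 25 nM, the higher of the two numbers, whereas compound 2 gives 5.4 nM. Compound 3 `N#C[C@H](COCc1ccccc1)NC(=O)[C@@H](CC(=O)N1CCOCC1)CC1CCCCC1` has not been measured. It differs from compound 1 by benzyloxy in place of benzyl on a saturated chain carbon, two bonds along the chain from an amide-type nitrogen and a triple-bonded carbon. For the measured compounds named here, no measured pair shows this change, so the step is expected to stay within the scatter or lean slightly toward a higher number. Compound 3 is therefore estimated at 30 nM in this assay, within 10 nM to 90 nM. The expected step of a 1.2-fold higher number from compound 1 to compound 3 (0.08 log units; within the scatter) is small.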

Compound 3, dissociation constant: 4.39 nM
For compound 3 the middle estimate is 6.8-fold (0.83 log units) above the measured one, outside the stated range (below it).
By their numbers in this assay, from the lowest: compounds 3 and 2 (each within the scatter of the next); then compound 1.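

For the compounds shown here, the first one-place step reads a 5.7-fold lower number from compound 1 to compound 3 (0.76 log units; beyond the scatter) in this assay for benzyloxy in place of benzyl on a saturated chain carbon, so this position responds to the change. The entering group adds a hydrogen-bond acceptor and one heavy atom, and this single pair cannot separate those two differences. No measurement on hand gives a reason for the step. On these data alone, whether an amine in place of the ether oxygen, or a longer chain ending in phenyl, would keep this step remains open. So does whether the same change carries over to the core of compound 2.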